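A few compounds are considered here, and "the series" means these few. Any claim that something is new, unique, unknown or untested is made for them only; others in the source may bear on it.

Within the data shown here, compound 1 `O=C(c1ccc(F)c(O)c1)c1ccc2cc(O)ccc2n1` is one of two compounds measured in an assay for inhibition of 17-beta-hydroxysteroid dehydrogenase type 2 (Homo sapiens), read by HPLC, with a stated time of 10 min, tested at 1 uM; a lower number here means less inhibition, a higher number more inhibition at the concentration tested (going by the name of the read-out). In this assay compound 1 gives 71%, the lower of the two numbers. Compound 2 `C=C(c1ccc(F)c(O)c1)c1cccc(-c2cccc(O)c2F)n1` gives 100% in this assay, a number higher than that of compound 1 by an amount beyond the usual scatter. Among the measured compounds shown here, no step between compounds that differ in a single place is available, so the two values can only be set side by side, and nothing is known about which part of either structure carries the difference.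

Compound 3 `Cc1ccc2nc(C(=O)c3ccc(F)c(O)c3)ccc2c1` has not yet been measured in this assay. It differs from compound 1 in one place: methyl in place of hydroxy on an aromatic carbon. The exchange sits on an aromatic carbon of the fused system of compound 1, meta to a fused ring and para to a fused ring.

For the measured compounds named here, because compound 1 stands at 71% and no measured pair shows the effect of this exchange, the expectation rests on compound 1 alone. Compound 3 is expected to give 45% in this assay, within a range from 15% to 75%. The step of a number 26 percentage points lower from compound 1 to compound 3 (beyond the scatter) is expected to run downward, by an amount beyond the scatter.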

Compound 3, a percentage reported as inhibition, at one concentration (the size of the read-out at that concentration, not a potency): 78%
Compound 3: middle estimate off by 33 percentage points, on the low side; the measured number lies above the stated range.
By their numbers in this assay, from the lowest: compounds 1 and 3 (each within the scatter of the next); then compound 2.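

In this assay, methyl in place of hydroxy on this aromatic carbon, meta to a fused ring and para to a fused ring, gives a number 7 percentage points higher from compound 1 to compound 3 (within the scatter), so the read-out does not separate compound 1 from compound 3. Among these compounds, this is the first single-place comparison, and it shows that, on this core, the read-out at the tested concentration holds when hydroxy, with its hydrogen-bond donor and acceptor, gives way to methyl, which has neither. No measurement is available that would explain this result.

What the compounds shown leave open is whether an amine, a methoxy group or a carboxylic acid on the same aromatic carbon would also leave the read-out within the scatter of compound 1, and whether a longer chain such as ethyl would do the same. The read-out also reports inhibition at one concentration rather than a potency, so this pair cannot show whether compound 1 and compound 3 would still match at other concentrations.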